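The source may report more compounds than this note shows. Statements on the series, on what has been measured and on what is new or still open speak of the compounds shown alone.

Of the compounds shown here, two sharing one core have been measured for how strongly they slow the growth of a stomach cancer cell line. Compound 1 `COc1ccc(CN(C(=O)CCCCSc2nc3ccccc3o2)c2cc(OC)c(OC)c(OC)c2)cc1` carries a benzoxazole joined through sulfur to a longer chain, and in a functional assay on MGC-803 cells (Homo sapiens) for antiproliferative activity, read by MTT assay, with a stated time of 48 h (on this read-out higher numbers stand for weaker inhibition and lower numbers for stronger inhibition), compound 1 gives 1360 nM. Compound 2 `COc1ccc(CN(C(=O)CSc2nnnn2C)c2cc(OC)c(OC)c(OC)c2)cc1` carries a 1-methyl-1H-tetrazol-5-yl on the sulfur of a shorter chain, and in this assay compound 2 gives 2490 nM. The two numbers sit within the usual scatter of each other, so neither compound can be called the weaker of the pair on this evidence.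

Compound 3 `COc1ccc(CN(C(=O)CSc2nc3ccccc3[nH]2)c2cc(OC)c(OC)c(OC)c2)cc1` is not yet measured. It keeps the shorter chain of compound 2 and differs only in 1H-benzimidazol-2-yl in place of 1-methyl-1H-tetrazol-5-yl on a sulfur. Going by the values given here, only two measured compounds exist here, so no step between them can be drawn on. The ring that enters resembles the two-ring heteroaromatic of compound 1, whose value 1360 nM lies close to that of compound 2, so a step from compound 2 to compound 3 of a 1.6-fold lower number from compound 2 to compound 3 (0.19 log units; within the scatter) in this assay is expected, no larger than the scatter. For compound 3 a value of 1600 nM is estimated, within 500 nM to 5000 nM.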

Compound 3, half-maximal inhibitory concentration: 1230 nM
Compound 3: middle estimate off by 1.3-fold (0.11 log units), on the high side; low and high end bracket the measured number.
By their numbers in this assay, from the lowest: compounds 3, 1 and 2 (each within the scatter of the next, the first and the last beyond it).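

Going by these compounds alone, on a sulfur whose other neighbour is a saturated chain carbon, putting 1H-benzimidazol-2-yl in place of 1-methyl-1H-tetrazol-5-yl gives a 2.0-fold lower number from compound 2 to compound 3 (0.31 log units; beyond the scatter) in this assay, a modest step and the first single-place change that can be read. It shows that the group on this sulfur can shift the read-out, but the swap alters several things at once: 9 heavy atoms enter where 6 leave, a six-membered aromatic ring of carbon only is added, and the count goes from 0 hydrogen-bond donors and 4 acceptors to 1 donor and 1 acceptor. No measurement available here links the step to any one of these differences.

From the compounds shown here alone, compound 1 differs from compound 3 in both the chain and the ring, so the separate contribution of chain length remains open. A 1-methyl-1H-benzimidazol-2-yl on the same sulfur would keep both rings of the new group while replacing its ring hydrogen with a methyl, and a simple phenyl would show how much of the step needs any ring nitrogen at all.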